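Benzyl in place of pentyl on the amide nitrogen

The source may hold more compounds than are shown below. What is called first, only, known or untested is meant among the compounds shown, and "the series" means these compounds.

Compound 1 `CCCCNC(=O)CC[C@H](NS(=O)(=O)c1ccc([N+](=O)[O-])cc1)C(=O)O`: 6360 nM
Compound 2 `CCCCCNC(=O)CC[C@H](NS(=O)(=O)c1ccc([N+](=O)[O-])cc1)C(=O)O`: 6800 nM

In an assay for inhibition of matrix metalloproteinase-9 (Homo sapiens), with stated times of 1 h, 1 min and 30 min (a lower number here means a stronger inhibitor, a higher number a weaker inhibitor), compound 1 gives 6360 nM and compound 2 gives 6800 nM. Among the compounds with values here, only two compounds have been measured, and the step of a 1.1-fold higher number from compound 1 to compound 2 (0.03 log units; within the scatter) leaves compound 2 and compound 1 within the scatter of each other. Compound 3 `O=C(CC[C@H](NS(=O)(=O)c1ccc([N+](=O)[O-])cc1)C(=O)O)NCc1ccccc1` carries phenyl in place of butyl on a saturated chain carbon bound to an amide-type nitrogen. Within the data shown here, the single measured step only added a methyl to the same chain and barely moved the number, so it bears weakly on replacing butyl with phenyl, and no measured step tests an aromatic ring at this place. The expected step of a 1.4-fold lower number from compound 2 to compound 3 (0.13 log units; within the scatter) is therefore small, leaning toward a lower number. Compound 3 is estimated at 5000 nM, within 1500 nM to 15000 nM.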

Compound 3, half-maximal inhibitory concentration: 6370 nM
For compound 3 the middle estimate is 1.3-fold (0.11 log units) below the measured one, and the stated range covers the measured number.
By their numbers in this assay, from the lowest: compounds 1, 3 and 2 (each within the scatter of the next).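

Phenyl in place of butyl on a saturated chain carbon bound to an amide-type nitrogen gives, in this assay, a 1.1-fold lower number from compound 2 to compound 3 (0.03 log units; within the scatter), and phenyl in place of propyl gives a 1.0-fold higher number from compound 1 to compound 3 (0.00 log units; within the scatter). So an aromatic ring at this place, tested here for the first time, gives a number that cannot be told apart from those of the two straight chains. No supporting data are available to explain this result. The compounds shown leave open whether a much longer chain, or an amine or a carboxylic acid on the phenyl ring, would move the number beyond the scatter.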